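Piperidin-1-yl in place of methylamino: clearance outlook

The compounds below may be only part of what the source reports. "The series", "measured", "known", "first", "only" and "open" are said of these compounds alone.

In an ADME assay on microsomes from liver (Mus musculus) for metabolic stability, read by HPLC, with a stated time of 4 h (on this read-out lower numbers stand for slow clearance and higher numbers for fast clearance), compound 2 `CNc1ccc2cc(-c3cc(Cl)cc(Cl)c3)c(N)nc2c1` gives < 10 mL/min/kg, which is a limit. Compound 2 therefore stands at the low-clearance end of the two values available. Compound 1 `CN(C)c1ccc2cc(-c3cc(Cl)ccc3Cl)c(N)nc2c1` gives > 500 mL/min/kg, also a limit. Compound 1 differs from compound 2 both in the amino group and in the chlorine pattern, so the pair isolates no single change.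

Compound 3 `Nc1nc2cc(N3CCCCC3)ccc2cc1-c1cc(Cl)cc(Cl)c1` carries piperidin-1-yl in place of methylamino on an aromatic carbon. Among the compounds with values here, no measured step covers this change. A rise well beyond the scatter is nevertheless expected in this assay, resting only on compound 1, which also lacks methylamino and gives the limit > 500 mL/min/kg. The expected size of the change is an at least 15-fold higher number from compound 2 to compound 3 (1.17 log units; beyond the scatter). The estimate for compound 3 is 150 mL/min/kg, with an expected range of 30 mL/min/kg to 500 mL/min/kg.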

Compound 3, clearance: 460 mL/min/kg
Beside the measured number, compound 3's estimate is 3.1-fold (0.49 log units) below it, and the stated range covers the measured number.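

In this assay, within the data shown here, piperidin-1-yl in place of methylamino gives an at least 46-fold higher number from compound 2 to compound 3 (1.66 log units; beyond the scatter) and is the first change in one place. With the rest of compound 3 matching compound 2, the high clearance can now be tied to the group on this aromatic carbon, whereas compound 1 also differs in its chlorine pattern. As far as these compounds go, the true size of the step stays unknown because compound 2 stands at a limit, not a number: the limit of < 10 mL/min/kg in this assay, at which 1 of the 3 values shown sits.

The compounds shown do not separate the ring of piperidin-1-yl from the loss of the hydrogen-bond donor carried by methylamino. Morpholin-4-yl and the open-chain diethylamino group at this position, on the same chlorine pattern, would help to tell these two differences apart.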